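The source may hold more compounds than are shown below. What is called first, only, known or untested is meant among the compounds shown, and "the series" means these compounds.

Measured so far in a functional assay on Maver1 cells (Homo sapiens) for inhibition, read by luminescence and CellTiter-Glo, with a stated time of 72 h; a higher number here means a weaker inhibitor, a lower number a stronger inhibitor: compound 1 `O=C(CCl)N1CCCC(n2nc(-c3ccc(Oc4ccccc4)cc3)cc2CO)C1` gives 1100 nM. Compound 2 `CCOC(=O)c1cc(-c2ccc(Oc3ccccc3)cc2)nn1Cc1cccc(NC(=O)CCl)c1` gives 500 nM. Compound 3 `C=CC(=O)N1CCCC(n2nc(-c3ccc(Oc4ccccc4)cc3)cc2C(=O)O)C1` returns no number, only a limit, > 60000 nM.

Compound 2 stands lowest of the two numbers; compound 1 lies higher, beyond the scatter. The third value sits at the limit of > 60000 nM in this assay, at which 1 of the 3 values shown sits, and is not compared further.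

Compound 4 `C=CC(=O)Nc1cccc(Cn2nc(-c3ccc(Oc4ccccc4)cc3)cc2C(=O)OCC)c1` differs from compound 2 by vinyl in place of chloromethyl on a carbonyl carbon. Among the compounds with values here, no measured pair covers this change. The expected step from compound 2 to compound 4 in this assay is a 2.0-fold higher number from compound 2 to compound 4 (0.30 log units; within the scatter), a modest move toward a higher number, possibly not beyond the scatter. Compound 4 is estimated at 1000 nM, between 250 nM and 5000 nM.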

Compound 4, half-maximal inhibitory concentration: 8600 nM
For compound 4 the middle estimate is 8.6-fold (0.93 log units) below the measured one; the measured number lies above the stated range.
By their numbers in this assay, from the lowest: compound 2; then compound 1; then compound 4. At a limit, above all of these: compound 3.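

In this assay, within the data shown here, the carbonyl carbon whose other neighbour is the amide-type nitrogen proves sensitive: vinyl in place of chloromethyl gives a 17-fold higher number from compound 2 to compound 4 (1.24 log units; beyond the scatter) and provides the first single-place comparison. On this core, the two groups are therefore not interchangeable. Nothing measured here accounts for the size of this step. Going by these compounds, whether the same change gives a step of this size on the core of compound 1 stays open. Also open, on these data alone, is how a longer chain in place of vinyl, or an amine carried on the vinyl group, would compare.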